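This account rests on a few compounds, and the source may have more. Where it says the series, first, only, none or still open, it means among the compounds named here.

Compound 1 `COc1cc(N2C(N)=C(C#N)C(c3ccc([N+](=O)[O-])cc3)C3=C2CC(C)(C)CC3=O)cc(OC)c1OC` gives 10% in a functional assay on Ehrlich cells (Mus musculus) for cytotoxicity, tested at 10 ug/mL; a higher number here means a stronger effect of the compound at the concentration tested, a lower number a weaker effect.
Compound 2 `COc1cc(N2C(N)=C(C#N)C(c3ccc(Cl)cc3Cl)C3=C2CC(C)(C)CC3=O)cc(OC)c1OC` gives 20% in this assay.
Compound 3 `COc1cc(N2C(N)=C(C#N)C(c3cccc([N+](=O)[O-])c3)C3=C2CC(C)(C)CC3=O)cc(OC)c1OC` gives 5% in this assay.

Compound 3 holds the lowest of the three numbers. Its nearest neighbour is compound 1, and the step of a number 5 percentage points lower from compound 1 to compound 3 (within the scatter) stays within the scatter, so the two cannot be put in order. Its furthest neighbour is compound 2, and the step of a number 15 percentage points lower from compound 2 to compound 3 (beyond the scatter) is beyond the scatter, though modest. The remaining step, a number 10 percentage points higher from compound 1 to compound 2 (within the scatter), also stays within the scatter. All three numbers are small for this kind of read-out.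

Compound 4 `COc1cc(N2C(N)=C(C#N)C(c3cccs3)C3=C2CC(C)(C)CC3=O)cc(OC)c1OC` differs from compound 3 in one place: thiophen-2-yl in place of 3-nitrophenyl on a saturated ring carbon. Among the compounds with values here, none of the measured steps exchanges the group on this saturated ring carbon for a thiophen-2-yl, so no step bears directly on this change. What the three steps do show is that swapping the group on this carbon moved the number only a little, and in the one case beyond the scatter only modestly. The step of a number 5 percentage points higher from compound 3 to compound 4 (within the scatter) is therefore expected to stay within the scatter. Compound 4 is estimated at 10%, with a range from 0% to 25%.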

Compound 4, a percentage reported as activity, at one concentration (the size of the read-out at that concentration, not a potency): 5%
Beside the measured number, compound 4's estimate is 5 percentage points above it; the range from low to high includes it.
By their numbers in this assay, from the lowest: compounds 3, 4, 1 and 2 (each within the scatter of the next, the first and the last beyond it).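

In this assay, a five-membered aromatic ring with sulfur on this saturated ring carbon reads much like the nitrophenyl rings, with no change at the digits printed from compound 3 to compound 4 (within the scatter) and a number 5 percentage points lower from compound 1 to compound 4 (within the scatter), so among these compounds neither a six-membered ring nor a nitro group is needed to reach this level. Only the 2,4-dichlorophenyl group stands somewhat apart from the thiophen-2-yl group, with a number 15 percentage points lower from compound 2 to compound 4 (beyond the scatter), and this modest step is the same size as the one printed for the 3-nitrophenyl group, a number 15 percentage points lower from compound 2 to compound 3 (beyond the scatter). No measurement at hand explains these numbers.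

Every group shown on this carbon is an aromatic ring, so the outcome with a cyclohexyl ring, a longer alkyl chain or a pyridine ring remains open. Also open, as far as these compounds go, is what happens when the 3,4,5-trimethoxyphenyl group on the ring nitrogen is exchanged for a plain phenyl ring.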